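Methyl on the aromatic nitrogen of compound 2

The compounds below may be only part of what the source reports. "The series", "measured", "known", "first", "only" and "open" are said of these compounds alone.

In an ADME assay on HEK-293T cells (Homo sapiens) for cytotoxicity, read by CCK-8 assay, with a stated time of 24 h (a higher number here means that more compound is tolerated, a lower number that less compound is tolerated), compound 1 (`CN(Cc1ccccc1)C(=O)CSc1c[nH]c2c(Br)cccc12`) gives 52500 nM. Compound 2 (`O=C(CSc1c[nH]c2ccccc12)NCc1ccc(C(F)(F)F)cc1`) gives > 100000 nM, which is a limit of the assay and not a number. Compound 3 (`Cn1cc(SCC(=O)NCc2ccc(C(F)(F)F)cc2)c2ccccc21`) carries methyl in place of hydrogen on an aromatic nitrogen. Going by the values given here, no measured pair isolates this change, so the expectation is tentative. The expected step is an at least 1.4-fold lower number from compound 2 to compound 3 (0.15 log units; that floor lies within the scatter), small and toward less compound tolerated in this assay, and possibly none beyond the scatter. For compound 3 the estimated value is 70000 nM, with an expected range from 30000 nM to 100000 nM.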

Compound 3, half-maximal cytotoxic concentration: > 100000 nM
Compound 3: no number, only a limit; the forecaster's own chance of this, stated with the estimate: 45%; at least 1.4-fold (0.15 log units) between middle value and limit.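

Compound 2 and compound 3 both give a limit of the assay and not a number, so no step between them can be read: the limit of > 100000 nM in this assay, at which 2 of the 3 values shown sit.

The compounds shown leave open whether methyl in place of hydrogen on an aromatic nitrogen changes how much compound is tolerated.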